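A Trifluoromethoxy Swap Beside an Assay Ceiling

This account rests on a few compounds, and the source may have more. Where it says the series, first, only, none or still open, it means among the compounds named here.

Compound 1 `O=C(/C=C/c1ccccc1F)c1ccccc1` and compound 2 `O=C(/C=C/c1ccccc1C(F)(F)F)c1ccccc1` share one core and differ at a single position on the ring that carries the substituent. In a functional assay on RAW264.7 cells (Mus musculus) for inhibition, read by fluorescence, with stated times of 1 h, 24 h and 30 min (a lower number here means a stronger inhibitor, a higher number a weaker inhibitor), compound 1 gives > 10000 nM, which is a limit of the assay and not a number. In this assay compound 2 gives > 10000 nM, again a limit and not a number. The step that the two limits leave unreadable from compound 1 to compound 2 therefore cannot be read, because both values sit at the limit of > 10000 nM in this assay, at which 2 of the 2 values shown sit.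

Compound 3 `O=C(/C=C/c1ccccc1OC(F)(F)F)c1ccccc1` has not yet been measured. Its change from compound 2 is trifluoromethoxy in place of trifluoromethyl on an aromatic carbon. Among the measured compounds shown here, only one measured step touches this position, and it is the unreadable one just described, so it sets neither a size nor a direction for the coming measurement. Compound 2 stands at the assay ceiling, and nothing measured argues for a drop below it.

In this assay compound 3 is therefore expected to land near 15000 nM, within the range 3000 nM to 60000 nM, most likely again reported only as a limit. The step that the limit leaves unreadable from compound 2 to compound 3 is the expected change.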

Compound 3, half-maximal inhibitory concentration: > 10000 nM
Compound 3: only a limit was reported (the forecaster's own chance of this, stated with the estimate: 85%); the middle value is on the limit's open side.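

In this assay, among the compounds shown here, compound 3 gives only a limit, not a number, so no step among compound 1, compound 2 and compound 3 can be read, because all their values sit at the same ceiling: the limit of > 10000 nM in this assay, at which 3 of the 3 values shown sit.

How strongly each of these compounds inhibits, and whether fluoro, trifluoromethyl and trifluoromethoxy differ at all in this assay, remains open.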